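Benzyl to (2-(trifluoromethyl)phenyl)carbonyl: compound 2 to compound 4

A few compounds are considered here, and "the series" means these few. Any claim that something is new, unique, unknown or untested is made for them only; others in the source may bear on it.

Antiproliferative potency in a functional assay on MCF7 cells (Homo sapiens) for antiproliferative activity, read by MTT assay, with a stated time of 72 h (on this read-out lower numbers stand for stronger inhibition and higher numbers for weaker inhibition), is weak across the whole small set. Compound 1 `CC1=CC[C@H]2[C@@H]1CC=C(C)[C@@H](CC[C@H]1[C@]3(C)CC[C@H](OC(=O)CCC(=O)O)C(C)(C)O[C@H]3CC[C@@]1(C)O)C2(C)C` gives only a limit of the assay, > 50000 nM. Compound 2 `CC1=CC[C@H]2[C@H](CC[C@]2(C)O)C(C)(C)[C@@H]1CC[C@H]1[C@]2(C)CC[C@H](OCc3ccccc3)C(C)(C)O[C@H]2CC[C@@]1(C)O` likewise yields no number and sits at the limit, > 50000 nM, so its place among the shown values is fixed solely by the limit of > 50000 nM in this assay, at which 2 of the 3 values shown sit. Compound 3 `CC1=CC[C@H]2[C@H](CC[C@]2(C)O)C(C)(C)[C@@H]1CC[C@H]1[C@]2(C)CC/C(=N/O)C(C)(C)O[C@H]2CC[C@@]1(C)O` is the single measurable entry, with 46800 nM in this assay. Compound 4 `CC1=CC[C@H]2[C@H](CC[C@]2(C)O)C(C)(C)[C@@H]1CC[C@H]1[C@]2(C)CC[C@H](OC(=O)c3ccccc3C(F)(F)F)C(C)(C)O[C@H]2CC[C@@]1(C)O` carries (2-(trifluoromethyl)phenyl)carbonyl in place of benzyl on an oxygen on a saturated carbon. Among the measured compounds shown here, no step between measured compounds exists to size this change, so the expected step is an at least 1.2-fold lower number from compound 2 to compound 4 (0.09 log units; that floor lies within the scatter), within the scatter and in no settled direction. For compound 4 the estimate in this assay is 40000 nM, ranging from 10000 nM to 200000 nM, with a real chance that only a limit is reported again.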

Compound 4, half-maximal inhibitory concentration: 19200 nM
Compound 4: middle estimate off by 2.1-fold (0.32 log units), on the high side; low and high end bracket the measured number.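

Among the compounds shown here, at the oxygen on a saturated carbon, (2-(trifluoromethyl)phenyl)carbonyl in place of benzyl gives the first change in the set that can be sized in this assay: an at least 2.6-fold lower number from compound 2 to compound 4 (0.41 log units; beyond the scatter). That step is a bound and not an exact size, since compound 2 gives only a limit of the assay: the limit of > 50000 nM in this assay, at which 2 of the 4 values shown sit.

The compounds shown do not separate the carbonyl from the trifluoromethyl group, so either could account for the step. On these data alone, how an unsubstituted phenylcarbonyl or a chain carrying an amine would read at this position remains open.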